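The source may hold more compounds than are shown below. What is called first, only, known or untested is meant among the compounds shown, and "the series" means these compounds.

Compound 1 `COc1cc(OCCOCCNC2CCCC2)ccc1OCc1ccccc1` gives 44600 nM in a functional assay on SK-OV-3 cells (Homo sapiens) for inhibition, read by CCK-8 assay, with a stated time of 70 h; on this read-out higher numbers stand for weaker inhibition and lower numbers for stronger inhibition.
Compound 2 `c1ccc(COc2ccc(OCCOCCOC3CCCC3)cc2)cc1` gives only a limit, > 100000 nM, in this assay.

Compound 2 thus stands at the limit of > 100000 nM in this assay, at which 1 of the 2 values shown sits, and has no number of its own, so compound 1 is the only one of the two with a measured value. The account turns to compound 3 `c1ccc(COc2ccc(OCCOCCNC3CC3)cc2)cc1`, which differs from compound 2 in one place: cyclopropylamino in place of cyclopentyloxy on a saturated chain carbon, two bonds along the chain from an oxygen on a saturated carbon. Going by the values given here, no step between measured compounds covers this change, so its size is not known from the data. Compound 1 also carries an amine on its chain and gives 44600 nM, so a step toward stronger inhibition in this assay is expected for this change, of modest size and perhaps not far beyond the scatter. Compound 3 is expected to give 60000 nM, within 20000 nM to 150000 nM, which means an expected step of an at least 1.6-fold lower number from compound 2 to compound 3 (0.22 log units; that floor lies within the scatter).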

Compound 3, half-maximal inhibitory concentration: 47200 nM
Beside the measured number, compound 3's estimate is 1.3-fold (0.10 log units) above it; measured number inside the range.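

In this assay, this position on the saturated chain, two bonds along from an oxygen on a saturated carbon, now has its first readable step: cyclopropylamino in place of cyclopentyloxy gives an at least 2.1-fold lower number from compound 2 to compound 3 (0.32 log units; beyond the scatter). The change therefore moves the read-out beyond the scatter, and compound 3 has a measured number in this series without the methoxy group of compound 1. The size of the step remains a floor, since compound 2 has no number of its own: the limit of > 100000 nM in this assay, at which 1 of the 3 values shown sits.

The ring and the atom linking it to the chain change together, so it remains open which of them accounts for the step, and a cyclopropyloxy group on the same chain would separate the two. As far as these compounds go, how a dimethylamino group or a longer chain would read in this assay also remains open.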